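From 3-fluorobenzyl to 2-bromobenzyl on the shared core

This account rests on a few compounds, and the source may have more. Where it says the series, first, only, none or still open, it means among the compounds named here.

In a functional assay on HUVEC cells (Homo sapiens) for antiproliferative activity, read by MTT assay, with a stated time of 24 h (a higher number here means a weaker inhibitor, a lower number a stronger inhibitor), compound 1 `COc1cc(OC)c(-c2coc3cc(OCc4ccccc4C#N)ccc3c2=O)cc1OC` reads > 10000 nM, which is a limit of the assay and not a number. For the measured compounds named here, compound 2 `COc1cc(OC)c(-c2coc3cc(OCc4cccc(F)c4)ccc3c2=O)cc1OC` gives 5300 nM, the only actual number so far. The change to compound 3 `COc1cc(OC)c(-c2coc3cc(OCc4ccccc4Br)ccc3c2=O)cc1OC` is 2-bromophenyl in place of 3-fluorophenyl on a saturated chain carbon bound to an oxygen on an aromatic ring, with 2-bromophenyl in place of 3-fluorophenyl on a saturated chain carbon bound to an oxygen on an aromatic ring. Going by the values given here, the only measured step at this place is an at least 1.8-fold lower number from compound 1 to compound 2 (0.27 log units; that floor lies within the scatter); it is a floor within the scatter and gives no firm size. With 2-cyanophenyl, compound 1 remains the sole case at a limit, so such a reading stays possible for compound 3. The expected step in this assay is small, toward a slightly higher number and within the scatter: a 1.2-fold higher number from compound 2 to compound 3 (0.09 log units; within the scatter). Compound 3 is estimated at 6500 nM, with an expected range of 2500 nM to 15000 nM.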

Compound 3, half-maximal inhibitory concentration: > 10000 nM
Compound 3: a limit, no number (the forecaster's own chance of this, stated with the estimate: 35%); at least 1.5-fold (0.18 log units) between middle value and limit.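

In this assay, 2-bromophenyl in place of 3-fluorophenyl on a saturated chain carbon bound to an oxygen on an aromatic ring gives an at least 1.8-fold higher number from compound 2 to compound 3 (0.27 log units; that floor lies within the scatter). Among these three compounds, 2-cyanophenyl in compound 1 and 2-bromophenyl in compound 3 both end at a limit of the assay, while only 3-fluorophenyl in compound 2 gives a number, and with that floor inside the scatter this is no firm difference. The step from compound 1 to compound 3 cannot be read, and the series at this place is still mostly bounded rather than sized: the limit of > 10000 nM in this assay, at which 2 of the 3 values shown sit.

A 2-fluorobenzyl or a 3-bromobenzyl group would be needed to separate the place on the ring from the identity of the group. On these data alone, it also remains open whether a benzyl ring carrying an amine would read differently from compound 2 at 5300 nM.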